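The compounds below may be only part of what the source reports. "The series", "measured", "known", "first", "only" and "open" are said of these compounds alone.

Compound 1 `O=C(NCc1ccccc1)c1cn(-c2ccccc2)nc1-c1cccnc1` was tested in a functional assay on MCF7 cells (Homo sapiens) for cytotoxicity, read by MTT assay, with a stated time of 48 h (on this read-out lower numbers stand for stronger inhibition and higher numbers for weaker inhibition), yet compound 1 returned "nd(insoluble)" (no result reported), so no number stands for it. Compound 2 `O=C(c1cn(-c2ccccc2)nc1-c1cccnc1)N1CCC(Cc2ccccc2)CC1` did give a reading: in this assay compound 2 shows 32200 nM, a weak effect. Compound 3 `COc1ccc(OC(=O)c2cn(-c3ccccc3)nc2-c2cccnc2)cc1` differs from compound 1 by 4-methoxyphenoxy in place of benzylamino on a carbonyl carbon. Going by the values given here, no measured step links these two compounds, and the only anchor for the series is compound 2 at 32200 nM in this assay. The change is expected to leave activity in the same weak region, with no step beyond the scatter that could be claimed. Compound 3 is therefore estimated at about 30000 nM, within a range from 8000 nM to 100000 nM.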

Compound 3, half-maximal inhibitory concentration: > 100000 nM
Compound 3: a limit, no number; the forecaster's own chance of this, stated with the estimate: 30%; middle value at least 3.3-fold (0.52 log units) from the limit.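

No step can be read from compound 1 to compound 3, since compound 1 has no number and compound 3 carries only a limit: the limit of > 100000 nM in this assay, at which 1 of the 3 values shown sits. The compounds shown leave open how strongly either compound acts, and whether 4-methoxyphenoxy in place of benzylamino changes activity at all.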